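The source may hold more compounds than are shown below. What is called first, only, known or untested is meant among the compounds shown, and "the series" means these compounds.

Measured so far:
- compound 1, `O=Cc1cc(O)c(O)c(Br)c1Br` — in a functional assay on HCT-116 cells (Homo sapiens) for cytotoxicity, read by MTT assay, with a stated time of 96 h (on this read-out lower numbers stand for stronger inhibition and higher numbers for weaker inhibition), compound 1 gives "not determined" (no result reported)
- compound 2, `CCOCc1cc(O)c(O)c(Br)c1Br` — 2510 nM

Going by the values given here, compound 2 carries the only number on record: in this assay compound 2 gives 2510 nM. Among the compounds with values here, compound 1 `O=Cc1cc(O)c(O)c(Br)c1Br` shares the core but was not read out, so it offers no comparison, and no step between measured compounds is available to calibrate the series.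

Compound 3 is `COCc1cc(O)c(O)c(Br)c1Br`. It differs from compound 2 by hydrogen in place of methyl on a saturated chain carbon bound to an oxygen on a saturated carbon; cut one bond further out, the change reads ethoxymethyl to methoxymethyl. Within the data shown here, with no measured step on file for any change on this chain, the shift is expected to be small: the step from compound 2 to compound 3 is estimated at a 1.1-fold higher number from compound 2 to compound 3 (0.05 log units; within the scatter), which is not expected to exceed the usual scatter in either direction. Compound 3 is therefore expected to give about 2800 nM in this assay, with a likely range of 1200 nM to 6500 nM.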

Compound 3, half-maximal inhibitory concentration: 14100 nM
Beside the measured number, compound 3's estimate is 5.0-fold (0.70 log units) below it; measured number above the stated range.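

In this assay the change from ethoxymethyl to methoxymethyl gives a 5.6-fold higher number from compound 2 to compound 3 (0.75 log units; beyond the scatter) and so counts as a real shift rather than scatter. Going by these compounds alone, this is the only measured step on this chain, and it shows that the outer end of the chain matters: removing one methyl weakens inhibition, with ethoxymethyl the better of this pair. No measured evidence on file accounts for the size of this step.

As far as these compounds go, the two numbers fix a direction for this pair only, so it stays open whether a longer chain such as propoxymethyl or butoxymethyl would continue the gain or lose it. Also open, from the compounds shown here alone, is how a hydroxymethyl, an aminomethyl or a carboxylic acid would read on the shared core.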